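The compounds below may be only part of what the source reports. "The series", "measured", "known", "first", "only" and "open" are said of these compounds alone.

In a functional assay on HeLa cells (Homo sapiens) for cytotoxicity, read by cell counting, with a stated time of 48 h (on this read-out higher numbers stand for an effect only at larger amounts of compound and lower numbers for an effect already at smaller amounts), three compounds built on a shared core have been measured. Compound 1 (`CCCCCCCCCC(=O)OC[C@H]1O[C@@H](n2ccc(N)nc2=O)[C@@H](O)[C@@H]1OC(=O)CCCCCCCCC`) gives 0.11 ug/mL in this test. Compound 3 (`CCCCCCCCCC(=O)OC[C@H]1O[C@@H](n2ccc(N)nc2=O)[C@@H](O)[C@@H]1O`) gives 0.1 ug/mL in the same test. Compound 2 (`C=CCCCCCCCCC(=O)O[C@H]1[C@H](O)[C@H](n2ccc(N)nc2=O)O[C@@H]1CO`) gives 0.05 ug/mL as its number, which is lower than the value of compound 1 by more than the usual scatter but within the scatter of compound 3.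

Compound 4 (`CCCCCCCCCCCC(=O)O[C@H]1[C@H](O)[C@H](n2ccc(N)nc2=O)O[C@@H]1CO`) differs from compound 2 by propyl in place of vinyl on a saturated chain carbon, eight bonds along the chain from a carbonyl carbon. Within the data shown here, no measured pair tests this swap directly. Among the measured compounds shown here, the one measured step concerns another change, hydrogen in place of nonylcarbonyl on an oxygen on a saturated carbon (a 1.1-fold lower number from compound 1 to compound 3 (0.04 log units; within the scatter)), and it stayed within the scatter. It offers only weak guidance, so no clear shift in either direction is expected in this assay from the swap. The estimated change is a small one (a 1.4-fold higher number from compound 2 to compound 4 (0.15 log units; within the scatter)), within the scatter. Compound 4 is estimated at 0.07 ug/mL (expected range 0.03 ug/mL to 0.2 ug/mL).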

Compound 4, concentration for half-maximal effect: 0.08 ug/mL
Compound 4: the middle estimate sits 1.1-fold (0.06 log units) below what was measured, and the stated range covers the measured number.
By their numbers in this assay, from the lowest: compounds 2, 4, 3 and 1 (each within the scatter of the next, the first and the last beyond it).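

In this assay, among these compounds, propyl in place of vinyl on a saturated chain carbon, eight bonds along the chain from a carbonyl carbon, gives a 1.6-fold higher number from compound 2 to compound 4 (0.20 log units; within the scatter) as the first direct reading of a change at this place. Going from vinyl to propyl removes a double bond and raises the group from 2 to 3 heavy atoms, yet this swap produces no shift that can be told apart from ordinary measurement scatter. Nothing measured alongside these compounds bears on why the step is so small.

The swap changes the double bond and the group size together, so the two changes cannot be read separately. Going by these compounds, whether an amine, a carboxylic acid or a longer chain at this place would shift the number beyond the scatter remains open.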